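This account rests on a few compounds, and the source may have more. Where it says the series, first, only, none or still open, it means among the compounds named here.

Compounds measured in an assay on VSM-A10 cells for antagonist activity at Endothelin-1 receptor (Rattus norvegicus); a lower number here means a stronger inhibitor, a higher number a weaker inhibitor:
compound 1 `CNc1cccc2c(S(=O)(=O)Nc3onc(C)c3C)cccc12` gives 130 nM;
compound 2 `Cc1noc(NS(=O)(=O)c2cccc3c(NCc4ccccc4)cccc23)c1C` gives 590 nM;
compound 3 `Cc1noc(NS(=O)(=O)c2cccc3c(CN(C)C)cccc23)c1C` gives 2800 nM.

Compound 3 stands highest of the three, weaker than compound 2 by a 4.7-fold higher number from compound 2 to compound 3 (0.68 log units; beyond the scatter) and than compound 1 by a 22-fold higher number from compound 1 to compound 3 (1.33 log units; beyond the scatter). Compound 4 `Cc1noc(NS(=O)(=O)c2cccc3c(C(C)(C)O)cccc23)c1C` has not been measured; it differs from compound 3 as follows: 1-hydroxy-1-methylethyl in place of (dimethylamino)methyl on an aromatic carbon. Among the measured compounds shown here, the two steps that bear on this position, a 22-fold higher number from compound 1 to compound 3 (1.33 log units; beyond the scatter) and a 4.7-fold higher number from compound 2 to compound 3 (0.68 log units; beyond the scatter), both end at compound 3 and show that (dimethylamino)methyl gave the weakest result among the groups tried there, but no measured compound carries 1-hydroxy-1-methylethyl. He therefore expects a step of a 1.9-fold lower number from compound 3 to compound 4 (0.27 log units; within the scatter), and estimates compound 4 at 1500 nM, within 400 nM to 6000 nM.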

Compound 4, half-maximal inhibitory concentration: 2890 nM
The estimate for compound 4 lay 1.9-fold (0.28 log units) below the measured number, within the range that was stated.
By their numbers in this assay, from the lowest: compound 1; then compound 2; then compounds 3 and 4 (each within the scatter of the next).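

In this assay, compound 3 and compound 4 stand within the scatter of each other (a 1.0-fold higher number from compound 3 to compound 4 (0.01 log units; within the scatter)), so the two groups on this aromatic carbon cannot be told apart, although 1-hydroxy-1-methylethyl brings a hydrogen-bond donor and (dimethylamino)methyl has none. Compound 4 also stands well above the two compounds with a nitrogen bound to this carbon (a 4.9-fold higher number from compound 2 to compound 4 (0.69 log units; beyond the scatter)) and (a 22-fold higher number from compound 1 to compound 4 (1.35 log units; beyond the scatter)), so the high number is no longer confined to compound 3. Nothing available explains these results.

The compounds shown leave open whether an unsubstituted amino group on this carbon would fall below compound 1. They also leave open whether a carboxylic acid there would stay with compound 3 and compound 4.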